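Replacing 4-cyanophenyl with isopropyl on compound 2

The source may hold more compounds than are shown below. What is called first, only, known or untested is meant among the compounds shown, and "the series" means these compounds.

Measured so far in a functional assay on U-373MG ATCC cells (Homo sapiens) for inhibition, read by MTT assay, with a stated time of 72 h; a higher number here means a weaker inhibitor, a lower number a stronger inhibitor:
- Compound 1 `CC1(C)CC(NC(=S)Nc2ccc(C#N)cc2)c2cc(F)ccc2O1` gives 11000 nM
- Compound 2 `CC1(C)CC(NC(=S)Nc2ccc(C#N)cc2)c2cc(Cl)ccc2O1` gives 10000 nM
- Compound 3 `CC1(C)CC(NC(=S)Nc2cccc([N+](=O)[O-])c2)c2cc(Br)ccc2O1` gives 4000 nM

Compound 2 sits with compound 1 at the high end of these numbers, and compound 3 gives a lower number. Compound 4 `CC(C)NC(=S)NC1CC(C)(C)Oc2ccc(Cl)cc21` differs from compound 2 in one place: isopropyl in place of 4-cyanophenyl on an amide-type nitrogen. Within the data shown here, the only measured step, a 1.1-fold lower number from compound 1 to compound 2 (0.04 log units; within the scatter), swaps fluoro for chloro, so it bears on this change only indirectly. Among the measured compounds shown here, no measured step replaces 4-cyanophenyl, so the expectation is uncertain, leaning towards a weaker inhibitor in this assay. The expected change is a 2.0-fold higher number from compound 2 to compound 4 (0.30 log units; within the scatter). For compound 4 the estimate is 20000 nM, with an expected range from 6000 nM to 70000 nM.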

Compound 4, half-maximal inhibitory concentration: 57000 nM
Compound 4: the middle estimate sits 2.9-fold (0.45 log units) below what was measured; the range from low to high includes it.
By their numbers in this assay, from the lowest: compound 3; then compounds 2 and 1 (each within the scatter of the next); then compound 4.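

In this assay, isopropyl in place of 4-cyanophenyl on the amide-type nitrogen gives a 5.7-fold higher number from compound 2 to compound 4 (0.76 log units; beyond the scatter), whereas the swap of fluoro for chloro gave only a 1.1-fold lower number from compound 1 to compound 2 (0.04 log units; within the scatter). The group on this nitrogen therefore affects the result, and of this pair, compound 2, with 4-cyanophenyl, is the stronger inhibitor. No measurement here explains the loss.

The compounds shown leave open whether the aromatic ring or its nitrile matters more. Plain phenyl would separate these two, while a longer chain such as n-hexyl would test whether a larger non-aromatic group can stand in for the ring.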